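Nitro-sulfone amides on HepG2 cells: three measured, one pending

This account rests on a few compounds, and the source may have more. Where it says the series, first, only, none or still open, it means among the compounds named here.

Compound 1 `CS(=O)(=O)c1ccc(C(=O)N2CCC(C(=O)N(Cc3ccccc3)c3ccccc3)CC2)cc1[N+](=O)[O-]`: > 27000 nM
Compound 2 `CN(Cc1cccc(F)c1)C(=O)CCCNC(=O)c1ccc(S(C)(=O)=O)c([N+](=O)[O-])c1`: > 27000 nM
Compound 3 `CN(Cc1ccccc1F)C(=O)CNC(=O)c1ccc(S(C)(=O)=O)c([N+](=O)[O-])c1`: 11400 nM

The read-out throughout is an ADME assay on HepG2 cells (Homo sapiens) for cytotoxicity, read by CellTiter-Glo and ATP content, with a stated time of 72 h; on this read-out higher numbers stand for an effect only at larger amounts of compound and lower numbers for an effect already at smaller amounts. For compound 1 the value is a limit of the assay, not a number. For compound 2 the value is likewise a limit. Only compound 3 gives a measured number in this assay. Two of the three values sit at the limit of > 27000 nM in this assay, at which 2 of the 3 values shown sit, so compound 2 stands at the limit together with compound 1, while compound 3 lies at a number. Among the compounds with values here, no step between measured compounds that differ in one place is available.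

Compound 4 `CC1CCN(C(=O)CCCNC(=O)c2ccc(S(C)(=O)=O)c([N+](=O)[O-])c2)CC1` differs from compound 2 in one place: 4-methylpiperidin-1-yl in place of (3-fluorobenzyl)(methyl)amino on a carbonyl carbon. With compound 2 at the limit, no change beyond the usual scatter is expected in this assay, and the step from compound 2 to compound 4 is estimated as a number no higher from compound 2 to compound 4 (the limit leaves the size open). Compound 4 is therefore expected to give 27000 nM in this assay, between 12000 nM and 60000 nM, most likely again reported only as a limit.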

Compound 4, half-maximal effective concentration: > 27000 nM
Compound 4: no number, only a limit; the forecaster's own chance of this, stated with the estimate: 75%; the middle value sits exactly at the limit.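

Compound 4 gives > 27000 nM in this assay and this is a limit of the assay, not a number. Within the data shown here, compound 2 also stands at a limit, so no step from compound 2 to compound 4 can be read. The compounds shown leave open whether 4-methylpiperidin-1-yl in place of (3-fluorobenzyl)(methyl)amino changes the value at all.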